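Three Salicylamide-Type Anilides and One Untested Pyridine Analogue

A few compounds are considered here, and "the series" means these few. Any claim that something is new, unique, unknown or untested is made for them only; others in the source may bear on it.

Measured in an ADME assay on A549 cells (Homo sapiens) for cytotoxicity, read by resazurin assay, with a stated time of 48 h; a higher number here means that more compound is tolerated, a lower number that less compound is tolerated:
compound 1 `CC(C)CNc1ccc(NC(=O)c2cc(Cl)ccc2O)c(Cl)c1`: 60000 nM
compound 2 `O=C(Nc1ccc(NCC2CC2)cc1Cl)c1cc(Cl)ccc1O`: 14400 nM
compound 3 `CN(C)c1ccc(CNc2ccc(NC(=O)c3cc(Cl)ccc3O)c(Cl)c2)cc1`: 24500 nM

Two steps show where compound 3 stands among these values: a 1.7-fold higher number from compound 2 to compound 3 (0.23 log units; within the scatter), and a 2.4-fold lower number from compound 1 to compound 3 (0.39 log units; beyond the scatter). The next analogue is compound 4 `O=C(Nc1ccc(NCc2ccc(O)nc2)cc1Cl)c1cc(Cl)ccc1O`, which has not yet been measured. In it, 6-hydroxypyridin-3-yl takes the place of 4-(dimethylamino)phenyl on a saturated chain carbon bound to a nitrogen on an aromatic ring: 6-hydroxypyridin-3-yl in place of 4-(dimethylamino)phenyl on a saturated chain carbon bound to a nitrogen on an aromatic ring.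

All three measured steps involve exchanges at this same place, and the largest is a 4.2-fold lower number from compound 1 to compound 2 (0.62 log units; beyond the scatter), which is still modest. Within the data shown here, none of the measured compounds carries a hydroxypyridine, so the data give no direction for this exchange. In this assay, no change beyond the scatter is therefore expected. The expected step is a 1.2-fold higher number from compound 3 to compound 4 (0.09 log units; within the scatter). For compound 4 the estimated value is 30000 nM, with an expected range of 12000 nM to 70000 nM.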

Compound 4, half-maximal cytotoxic concentration: 98500 nM
Compound 4: the middle estimate sits 3.3-fold (0.52 log units) below what was measured; the whole stated range lies below it.
By their numbers in this assay, from the lowest: compounds 2 and 3 (each within the scatter of the next); then compounds 1 and 4 (each within the scatter of the next).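

In this assay, among these compounds, swapping one six-membered aromatic ring for another at this place on a saturated chain carbon bound to a nitrogen on an aromatic ring is not a neutral exchange, as a 4.0-fold higher number from compound 3 to compound 4 (0.60 log units; beyond the scatter) lies beyond the scatter, something the earlier steps among alkyl and phenyl groups could not show. Among the compounds shown here, the new group also separates clearly from cyclopropyl, with a 6.8-fold higher number from compound 2 to compound 4 (0.84 log units; beyond the scatter) beyond the scatter, while a 1.6-fold higher number from compound 1 to compound 4 (0.22 log units; within the scatter) stays within it, so 6-hydroxypyridin-3-yl is the only aromatic group here that matches the isopropyl compound. Nothing available explains why the exchange from 4-(dimethylamino)phenyl shifts the number.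

Still open, on these data alone, is whether the ring nitrogen or the hydroxyl carries this step, which a plain pyridin-3-yl and a 4-hydroxyphenyl would separate. Also open, as far as these compounds go, is how a carboxylic acid on the same ring would fare.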